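This account rests on a few compounds, and the source may have more. Where it says the series, first, only, none or still open, it means among the compounds named here.

Measured compounds:

Compound 1 `O=c1[nH]c2ccc(Cl)cc2c(-c2ccccc2Cl)c1CCO` gives 388000 nM in an ADME assay on HepG2 2.2.15 cells (Homo sapiens) for cytotoxicity; on this read-out lower numbers stand for higher toxicity in this test and higher numbers for lower toxicity in this test.
Compound 2 `CC(C)(C)[Si](CCc1c(OCc2c(F)cccc2F)nc2ccc(Cl)cc2c1-c1ccccc1Cl)(c1ccccc1)c1ccccc1` reaches only a limit of the assay in this assay, > 1860000 nM.
Compound 3 `OCCc1c(OCc2c(F)cccc2F)nc2ccc(Cl)cc2c1-c1ccccc1Cl` gives 109000 nM in this assay.

Of the three, compound 2 stands apart: its result is not a number but a limit, (the limit of > 1860000 nM in this assay, at which 1 of the 3 values shown sits), so its toxicity is known only to be lower than the other two can be compared against. Compound 1 and compound 3 each give a number, and both lie far below that limit.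

The next compound keeps the silyl-bearing side chain of compound 2 and alters the group next to the ring nitrogen: piperidin-1-yl in place of (2,6-difluorobenzyl)oxy on an aromatic carbon. This gives compound 4 `CC(C)(C)[Si](CCc1c(N2CCCCC2)nc2ccc(Cl)cc2c1-c1ccccc1Cl)(c1ccccc1)c1ccccc1`.

No measured step of this kind is available among the compounds shown, so the expected size of the step from compound 2 to compound 4 is uncertain; a change of an at least 1.2-fold lower number from compound 2 to compound 4 (0.09 log units; that floor lies within the scatter) is expected, which is no step beyond the scatter, since the bulky silyl chain shared with compound 2 remains in place. Compound 4 is therefore estimated at 1500000 nM, with a range from 500000 nM to 3500000 nM, and a fair chance that only a limit is reported again.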

Compound 4, half-maximal cytotoxic concentration: > 968000 nM
Compound 4 gave a limit, no number; the forecaster's own chance of this, stated with the estimate: 55%; the middle value does not contradict the limit.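

No step can be read from compound 2 to compound 4, since each gives only a limit of the assay and not a number. The compounds shown leave open whether piperidin-1-yl in place of (2,6-difluorobenzyl)oxy changes the result in this assay, and in which direction.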